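The compounds below may be only part of what the source reports. "The series", "measured", "known", "first", "only" and "open" are said of these compounds alone.

In a functional assay on K562 cells (Homo sapiens) for inhibition, read by sulforhodamine B assay, with a stated time of 48 h, tested at 10 uM (on this read-out lower numbers stand for a stronger effect and higher numbers for a weaker effect at the one concentration tested), compound 1 `O=C(Nc1cccc(-n2cc(-c3ccncc3)c(-c3cc(O)cc(Cl)c3)n2)c1)Nc1ccc(Cl)c(C(F)(F)F)c1` gives 5.24% and compound 2 `O=C(Nc1cccc(-n2cc(-c3ccncc3)c(-c3cc(O)cc(Cl)c3)n2)c1)Nc1ccc(Cl)c(Cl)c1` gives 1.06%. Going by the values given here, the only step traced so far, a number 4.2 percentage points lower from compound 1 to compound 2 (within the scatter), is within the scatter, so compound 2 and compound 1 sit together at the strong end of this assay and no order between them can be read from the numbers.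

Compound 3 `COc1cc(Cl)cc(-c2nn(-c3cccc(NC(=O)Nc4ccc(Cl)c(Cl)c4)c3)cc2-c2ccncc2)c1` differs from compound 2 by methyl in place of hydrogen on an oxygen on an aromatic ring. Among the compounds with values here, no measured step bears on this change: the single step traced involves a different group on a different ring, and the pair of numbers carries no information on what the oxygen on the aromatic ring contributes. The expectation therefore rests only on the structural change and on the position of compound 2 near the floor of this assay, from which any move has room only upward. The step from compound 2 to compound 3 is estimated as a number 10.9 percentage points higher from compound 2 to compound 3 (beyond the scatter), with a wide range. Compound 3 is expected to give 12% in this assay, between 0% and 45%.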

Compound 3, a percentage reported as activity, at one concentration (the size of the read-out at that concentration, not a potency): 10%
For compound 3 the middle estimate is 2 percentage points above the measured one, and the stated range covers the measured number.
By their numbers in this assay, from the lowest: compounds 2, 1 and 3 (each within the scatter of the next).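

In this assay, the step on the oxygen reads a number 8.9 percentage points higher from compound 2 to compound 3 (within the scatter), so hydroxy and methoxy on this ring cannot be told apart at the one concentration tested. Going by these compounds alone, this is the first information on this position, since the earlier pair differed only on the other aromatic ring, and it shows that methyl can replace the hydrogen on this oxygen without a step beyond the scatter. No measurement shown bears on why the read-out stays within the scatter across this change.

The compounds shown leave open whether a longer chain on this oxygen, such as ethyl or propyl, or an amine in place of the hydroxy group would keep the read-out in the same range. A single concentration also leaves open whether compound 2 and compound 3 would separate at lower concentrations.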